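Ester chain in place of isopropyl on the ring nitrogen substituent

The source may hold more compounds than are shown below. What is called first, only, known or untested is meant among the compounds shown, and "the series" means these compounds.

Compound 2 `CC(C)C[N+]1(C)CCc2c(sc(NC(=O)Nc3ccc(Cl)cc3)c2C(N)=O)C1` gives 380 nM in a functional assay (strain AB) with Danio rerio as the target, read by microscopy, with a stated time of 1 h; a lower number here means that less compound is needed, a higher number that more compound is needed for the effect. Compound 1 `CC(C)(C)OC(=O)CCC[N+]1(C)CCc2c(sc(NC(=O)Nc3ccc(Cl)cc3)c2C(N)=O)C1` differs by 2-(tert-butoxycarbonyl)ethyl in place of isopropyl on a saturated chain carbon bound to an amine nitrogen in a ring and gives 250 nM; the step is a 1.5-fold lower number from compound 2 to compound 1 (0.18 log units; within the scatter). Compound 3 `CC(C)CN1CCc2c(sc(NC(=O)Nc3ccc(Cl)cc3)c2C(N)=O)C1` has a different core from compound 2, and the difference between the two cores is not broken down here; in this assay compound 3 gives 4510 nM, the highest number of the three measured. Compound 4 `CC(C)(C)OC(=O)CCCN1CCc2c(sc(NC(=O)Nc3ccc(Cl)cc3)c2C(N)=O)C1` is not yet measured and differs from compound 3 by 2-(tert-butoxycarbonyl)ethyl in place of isopropyl on a saturated chain carbon bound to an amine nitrogen in a ring, the same change as from compound 2 to compound 1. Because a 1.5-fold lower number from compound 2 to compound 1 (0.18 log units; within the scatter) stayed within the scatter, a comparably small step, a 1.4-fold lower number from compound 3 to compound 4 (0.14 log units; within the scatter), is expected for compound 4. Compound 4 is therefore expected to give about 3300 nM, with a likely range from 1400 nM to 8000 nM.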

Compound 4, half-maximal effective concentration: 560 nM
Compound 4: middle estimate off by 5.9-fold (0.77 log units), on the high side, and the stated range ends above it.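

In this assay the change from isopropyl to 2-(tert-butoxycarbonyl)ethyl gives an 8.1-fold lower number from compound 3 to compound 4 (0.91 log units; beyond the scatter) on the core of compound 3, and the size of the step does not carry over from the core of compound 2: the same change on two cores in this assay, a 1.5-fold lower number (0.18 log units; within the scatter) from compound 2 to compound 1 and an 8.1-fold lower number (0.91 log units; beyond the scatter) from compound 3 to compound 4, 5.3-fold (0.72 log units) apart, beyond the scatter of two such steps. In this series, a step read on one of these cores therefore gives no reliable size for the same change on the other. Two pairs do not show why the steps differ, nor how the change behaves on any further core.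

Still open, as far as these compounds go, is whether the ester itself or the chain accounts for the larger step. A carboxylic acid or a longer plain alkyl chain, compared on both cores, would bear on this.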